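Bromo to Fluoro: a Small Change, Little Expected Effect

This account rests on a few compounds, and the source may have more. Where it says the series, first, only, none or still open, it means among the compounds named here.

Of the compounds shown here, two have so far been measured in a functional assay on HepG2 cells (Homo sapiens) for inhibition, read by MTT assay, with a stated time of 48 h, tested at 10 uM; on this read-out lower numbers stand for less inhibition of growth and higher numbers for more inhibition of growth at the one concentration tested. Compound 1 `C#CCOc1ccc(/C=C/C(=O)c2ccc([N+](=O)[O-])cc2)cc1` gives 27% there. Compound 2 `O=C(/C=C/c1ccc(OCc2cn(Cc3ccccc3Br)nn2)cc1)c1ccc(Br)cc1` gives 34% in this assay, and this value and that of compound 1 lie within the usual scatter of each other, so the two compounds cannot be placed in any order on these numbers.

Compound 3 `O=C(/C=C/c1ccc(OCc2cn(Cc3ccccc3F)nn2)cc1)c1ccc(Br)cc1` has not yet been tested. It differs from compound 2 in one place: fluoro in place of bromo on an aromatic carbon. Among the measured compounds shown here, no pair of measured compounds shows the effect of such a swap, so there is no measured step to lean on. For the measured compounds named here, one halogen replaces another at the same spot of the same ring, and nothing among the measured compounds points to a large shift. The expected step of a number 4 percentage points lower from compound 2 to compound 3 (within the scatter) is therefore small, with no direction beyond the scatter. Compound 3 is expected to give 30% in this assay, estimated to lie between 15% and 45%.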

Compound 3, percent growth inhibition at one concentration: 29%
Estimate against measurement, compound 3: 1 percentage points above; measured number inside the range.
By their numbers in this assay, from the lowest: compounds 1, 3 and 2 (each within the scatter of the next).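

In this assay, among the compounds shown here, changing 2-bromobenzyl to 2-fluorobenzyl gives the first measured step for any change at this position, a number 5 percentage points lower from compound 2 to compound 3 (within the scatter), and this step does not separate the two compounds. At the one concentration tested, bromo and fluoro at this place on the ring therefore cannot be told apart by their growth inhibition. No measurement at hand offers an explanation for this result.

From the compounds shown here alone, both compounds carry a halogen at this position, so it remains open whether a different kind of group there, such as an amine, a carboxylic acid or a longer chain, would shift the number beyond the scatter. Going by these compounds, it also remains open whether the same swap would make as little difference for the bromo on the other aromatic ring of the shared core.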